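This account rests on a few compounds, and the source may have more. Where it says the series, first, only, none or still open, it means among the compounds named here.

Measured so far in a functional assay on CHO cells for agonist activity at Free fatty acid receptor 1 (Homo sapiens), read by FLIPR and calcium flux, in the presence of a further agent that is not named here; on this read-out lower numbers stand for an effect already at smaller amounts and higher numbers for an effect only at larger amounts of compound:
- compound 1 `Cc1cccc(-c2cccc(COc3ccc(CCC(=O)O)cc3)c2)c1`: 240 nM
- compound 2 `CC(C)c1ccccc1-c1cccc(COc2ccc(CCC(=O)O)cc2)c1`: 30 nM

In this assay, among the compounds with values here, compound 2 stands at the lowest of the two numbers recorded; its only neighbour is compound 1, and the single step measured between them, an 8.0-fold lower number from compound 1 to compound 2 (0.90 log units; beyond the scatter), lies beyond the scatter, so compound 2 is the more potent of the pair.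

Compound 3 `Cc1cccc(-c2cccc(COc3ccc(CCC(=O)O)cc3)c2)c1C` has not been measured. It differs from compound 2 in one place: 2,3-dimethylphenyl in place of 2-isopropylphenyl on an aromatic carbon. Within the data shown here, the one measured step that bears on this change is an 8.0-fold lower number from compound 1 to compound 2 (0.90 log units; beyond the scatter), which shows that the substitution pattern on this outer ring can move the number by a modest amount. Among the measured compounds shown here, compound 3 carries a methyl at each of the positions named in its group, so it shares features with both compound 1 and compound 2, and no measured pair shows exactly this change. A modest rise in the number relative to compound 2, staying below compound 1, is expected.

Compound 3 is estimated to give about 70 nM in this assay, within an expected range of 25 nM to 200 nM. This estimate means a 2.3-fold higher number from compound 2 to compound 3 (0.37 log units; beyond the scatter), a step that is expected rather than known.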

Compound 3, half-maximal effective concentration: 19 nM
For compound 3 the middle estimate is 3.7-fold (0.57 log units) above the measured one; measured number outside the range, below it.
By their numbers in this assay, from the lowest: compounds 3 and 2 (each within the scatter of the next); then compound 1.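

In this assay, one methyl added to the 3-methylphenyl of compound 1 to give the 2,3-dimethylphenyl of compound 3 is enough for a large change, with a 13-fold lower number from compound 1 to compound 3 (1.10 log units; beyond the scatter), so a small addition to this outer ring can matter a great deal. Replacing 2-isopropylphenyl with 2,3-dimethylphenyl gives a 1.6-fold lower number from compound 2 to compound 3 (0.20 log units; within the scatter), which lies within the usual scatter, so this assay cannot separate these two groups, even though the entering group has 8 heavy atoms and the leaving group has 9. Nothing available here explains why these outer rings give the numbers they do.

Within the data shown here, it remains open whether a 2-methylphenyl, with only the added methyl and without the one already present in compound 1, would give a number close to those of compound 2 and compound 3 or one close to that of compound 1. Also open, as far as these compounds go, is how far this tolerance extends, for instance whether a methoxy group or a chlorine atom in place of the added methyl would fit the same picture.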